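Aryl swap on the enone in a cytotoxicity screen

The compounds below may be only part of what the source reports. "The series", "measured", "known", "first", "only" and "open" are said of these compounds alone.

Compound 1, `COC(=O)c1cc(-c2cccc(NC(=O)c3ccc(/C=C/C(=O)c4cccc(F)c4)cc3)c2)on1`, in an ADME assay on Vero cells (Chlorocebus sabaeus) for cytotoxicity, read by MTT assay, with a stated time of 72 h (on this read-out higher numbers stand for lower toxicity in this test and lower numbers for higher toxicity in this test), gives > 40 ug/mL, which is a limit of the assay and not a number. Compound 2, `COC(=O)c1cc(-c2cccc(NC(=O)c3ccc(/C=C/C(=O)c4cc(F)ccc4F)cc3)c2)on1`, in this assay gives > 40 ug/mL, again a limit of the assay.

Compound 2 therefore stands at the top of what the assay can report, and it shares that position with compound 1: both values sit at the limit of > 40 ug/mL in this assay, at which 2 of the 2 values shown sit. For the measured compounds named here, the single measured step, a step that the two limits leave unreadable from compound 1 to compound 2, cannot be read because both of its ends are limits, so it gives no size and no direction.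

Compound 3, `COC(=O)c1cc(-c2cccc(NC(=O)c3ccc(/C=C/C(=O)c4ccccc4OC)cc3)c2)on1`, arises from compound 2 by the change (2-methoxyphenyl in place of 2,5-difluorophenyl on a carbonyl carbon). Going by the values given here, the only measured step that touches the ring on that carbonyl carbon is the one from compound 1 to compound 2, and it is unreadable, so nothing measured here points to a shift in this assay in either direction. Among the compounds with values here, the expectation is that compound 3 will again reach the limit, with no step readable beyond the scatter. The expected step is a step that the limit leaves unreadable from compound 2 to compound 3. Compound 3 is estimated to give about 50 ug/mL, within a range from 25 ug/mL to 120 ug/mL.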

Compound 3, half-maximal cytotoxic concentration: > 40 ug/mL
Compound 3 gave a limit, no number (the forecaster's own chance of this, stated with the estimate: 80%); the middle value lies beyond the limit too.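

In this assay compound 3 also gives a limit of the assay and not a number, so neither its step from compound 1 nor its step from compound 2 can be read: the limit of > 40 ug/mL in this assay, at which 3 of the 3 values shown sit.

The compounds shown leave open whether the rings on the carbonyl carbon differ at all in this assay, and by how much.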